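From 4-bromophenyl to 4-hydroxyphenyl in the series

This account rests on a few compounds, and the source may have more. Where it says the series, first, only, none or still open, it means among the compounds named here.

Compound 1 `C#CCSc1nc(Nc2ccc(F)cc2)c2ccncc2n1` gives 17300 nM in a functional assay on PC-3 cells (Homo sapiens) for inhibition, read by MTT assay, with a stated time of 72 h; a higher number here means a weaker inhibitor, a lower number a stronger inhibitor. Compound 2 `C#CCSc1nc(Nc2ccc(Br)cc2)c2ccncc2n1` gives 26000 nM in this assay; this is the higher of the two numbers, though the step of a 1.5-fold higher number from compound 1 to compound 2 (0.18 log units; within the scatter) stays within the scatter. Compound 3 `C#CCSc1nc(Nc2ccc(O)cc2)c2ccncc2n1` is not yet measured; the change is hydroxy in place of bromo on an aromatic carbon. Within the data shown here, no measured step exchanges a halogen for hydroxy, and the single known step, fluoro to bromo, is within the scatter, so no shift beyond the scatter is expected. Compound 3 is therefore estimated at 20000 nM in this assay, with a range from 7000 nM to 60000 nM. For compound 3 the expected step is a 1.3-fold lower number from compound 2 to compound 3 (0.11 log units; within the scatter).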

Compound 3, half-maximal inhibitory concentration: > 80000 nM
Compound 3 was reported as a limit (the forecaster's own chance of this, stated with the estimate: 10%); middle value at least 4.0-fold (0.60 log units) away from the limit.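

This position is not indifferent to what it carries: fluoro and bromo differ only within the scatter, whereas hydroxy gives a step beyond it, with an at least 3.0-fold higher number from compound 2 to compound 3 (0.48 log units; beyond the scatter) and an at least 4.6-fold higher number from compound 1 to compound 3 (0.66 log units; beyond the scatter). Compound 3 in this assay is a limit and not a number, so both steps give only a lower bound on the shift: the limit of > 80000 nM in this assay, at which 1 of the 3 values shown sits.

The compounds shown leave open whether this shift belongs to hydroxy alone. An amine, a methoxy or a carboxylic acid at the same place would test that.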